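Swapping Dimethylamino for Hydroxyoxetanyl: Expected Microsomal Half-Life

The source may hold more compounds than are shown below. What is called first, only, known or untested is meant among the compounds shown, and "the series" means these compounds.

Measured compounds:
Compound 1, `CC(C)(C)c1ccc(C(=O)NCc2c(Cl)cc(NS(C)(=O)=O)cc2Cl)cc1`: 1.37 h
Compound 2, `CN(C)c1ccc(C(=O)NCc2ccc(NS(C)(=O)=O)cc2Cl)cc1`: 0.883 h

Both compounds were tested in an ADME assay on microsomes from liver (Rattus norvegicus, strain Sprague-Dawley) for metabolic stability, read by HPLC, using NADPH, with stated times of 5 min and 60 min, tested at 10 uM; a higher number here means that the compound lasts longer, a lower number that the compound disappears faster. Compound 2 and compound 1 give numbers that lie within the usual scatter of each other, so on these two values neither can be said to last longer or to disappear faster; compound 2 simply sits alongside compound 1.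

Compound 3, `CS(=O)(=O)Nc1ccc(CNC(=O)c2ccc(C3(O)COC3)cc2)c(Cl)c1`, has not been measured. Its difference from compound 2 is a single change:

3-hydroxyoxetan-3-yl in place of dimethylamino on an aromatic carbon

Going by the values given here, no pair of measured compounds shares this change, so there is no step to lean on. For the step from compound 2 to compound 3, the expectation is a small rise in half-life that may not exceed the scatter: a 1.5-fold higher number from compound 2 to compound 3 (0.17 log units; within the scatter). Compound 3 is therefore expected to give roughly 1.3 h, with a plausible range from 0.7 h to 2.6 h.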

Compound 3, half-life: 4.23 h
For compound 3 the middle estimate is 3.3-fold (0.51 log units) below the measured one; the whole stated range lies below it.
By their numbers in this assay, from the lowest: compounds 2 and 1 (each within the scatter of the next); then compound 3.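

In this assay, putting 3-hydroxyoxetan-3-yl in place of dimethylamino on an aromatic carbon, para to a large group, gives a 4.8-fold higher number from compound 2 to compound 3 (0.68 log units; beyond the scatter). Going by these compounds alone, until now no two compounds differing in one place were available, so this is the first sign that the group at this position can change how long a compound lasts in this test. Nothing in the data shown tells why the half-life rises.

A single step cannot separate the loss of dimethylamino from the arrival of 3-hydroxyoxetan-3-yl. Still open, as far as these compounds go, is how a smaller group at this position, such as a hydroxyl or a methoxy group, would compare, and whether the same exchange would have a similar effect on the core of compound 1.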